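Swapping methylsulfanyl for bromine on the hydrazone phenyl ring

A few compounds are considered here, and "the series" means these few. Any claim that something is new, unique, unknown or untested is made for them only; others in the source may bear on it.

In a physicochemical assay for lipophilicity, measured as octanol-water partition (on this read-out higher numbers stand for higher lipophilicity and lower numbers for lower lipophilicity), compound 1 `O=C(COc1cccc2ccccc12)N/N=C/c1cccc([N+](=O)[O-])c1` gives 3.97, and compound 2 `CSc1ccc(/C=N/NC(=O)COc2cccc3ccccc23)cc1` gives 4.11. Compound 2 holds the larger of these two numbers, but the gap to compound 1 is within the scatter, so the two are effectively the same. Compound 3 `O=C(COc1cccc2ccccc12)N/N=C/c1cccc(Br)c1` has not yet been measured in this assay. It differs from compound 2 by 3-bromophenyl in place of 4-(methylsulfanyl)phenyl on a carbon with a double bond to nitrogen. For the measured compounds named here, no measured step of this kind is available, so the expectation rests on the change alone: the estimated step is a number 0.19 log units higher from compound 2 to compound 3 (within the scatter), a slight rise that probably stays within the scatter. Compound 3 is therefore expected to give about 4.3, between 3.9 and 4.7.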

Compound 3, partition coefficient: 4.81
The estimate for compound 3 lay 0.51 log units below the measured number; measured number above the stated range.
By their numbers in this assay, from the lowest: compounds 1 and 2 (each within the scatter of the next); then compound 3.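

In this assay, 3-bromophenyl in place of 4-(methylsulfanyl)phenyl gives a number 0.70 log units higher from compound 2 to compound 3 (beyond the scatter) and so shows a real difference at this place, which compounds 1 and 2 alone could not show. Bromo in place of nitro on an aromatic carbon likewise gives a number 0.84 log units higher from compound 1 to compound 3 (beyond the scatter) and sets compound 3 apart from both. On these data alone, whether the gain follows the bromine itself or its ring position stays open, as does what a carboxylic acid or an amine on that ring would give. No measurement shown here explains the rise.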